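A few compounds are considered here, and "the series" means these few. Any claim that something is new, unique, unknown or untested is made for them only; others in the source may bear on it.

Compound 1 `CCCCCC(=O)Nc1ccc(S(=O)(=O)Oc2ccccc2I)cc1` gives 13000 nM in a functional assay on HT-29 cells (Homo sapiens) for antiproliferative activity, read by sulforhodamine B assay, with a stated time of 48 h; on this read-out higher numbers stand for weaker inhibition and lower numbers for stronger inhibition.
Compound 2 `CC(C)C(=O)Nc1ccc(S(=O)(=O)Oc2ccccc2I)cc1` gives 13000 nM in this assay.
Compound 3 `CC(C)c1ccccc1OS(=O)(=O)c1ccc(NC(=O)CCl)cc1` gives 5600 nM in this assay.

Compound 3 holds the lowest of the three numbers in this assay, and both compound 1 and compound 2 sit above it by more than the scatter. Compound 4 `O=C(CCl)Nc1ccc(S(=O)(=O)Oc2ccccc2I)cc1` differs from compound 3 by iodo in place of isopropyl on an aromatic carbon. Going by the values given here, the only measured step, no change at the digits printed from compound 1 to compound 2 (within the scatter), changes the amide chain and leaves the aromatic ring untouched, so it does not speak to this change. Compound 1 and compound 2, which carry the iodo group alongside other amides, both give higher numbers than compound 3. A modest step toward weaker inhibition is therefore expected for compound 4: a 1.4-fold higher number from compound 3 to compound 4 (0.15 log units; within the scatter). Compound 4 is estimated at 8000 nM, within a range from 3000 nM to 20000 nM.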

Compound 4, half-maximal inhibitory concentration: 4100 nM
For compound 4 the middle estimate is 2.0-fold (0.29 log units) above the measured one; the measured number falls inside the stated range.
By their numbers in this assay, from the lowest: compounds 4 and 3 (each within the scatter of the next); then compounds 1 and 2 (each within the scatter of the next).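

In this assay swapping isopropyl for iodo on this aromatic carbon gives a 1.4-fold lower number from compound 3 to compound 4 (0.14 log units; within the scatter) and so does not separate the two groups. With iodo kept, the amide chain does matter: chloromethyl in place of isopropyl gives a 3.2-fold lower number from compound 2 to compound 4 (0.50 log units; beyond the scatter) and chloro in place of butyl gives a 3.2-fold lower number from compound 1 to compound 4 (0.50 log units; beyond the scatter) on the same read-out. Nothing available here explains these steps.

From the compounds shown here alone, whether a methoxy group or a carboxylic acid on this aromatic carbon would match iodo and isopropyl stays open. So does how a bromoacetyl or plain acetyl amide would compare with the chloromethyl amide.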